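Three sulfonamides at the assay limit, a fourth to come

A few compounds are considered here, and "the series" means these few. Any claim that something is new, unique, unknown or untested is made for them only; others in the source may bear on it.

Compound 1 `O=S(=O)(Nc1ccc(-c2nc3ccccc3o2)cc1)c1cccc(F)c1`; in an assay on isolated protein for inhibition of malate dehydrogenase, mitochondrial (Sus scrofa), with stated times of 45 min and 30 min (on this read-out higher numbers stand for weaker inhibition and lower numbers for stronger inhibition), compound 1 gives only a limit, > 63000 nM.
Compound 2 `C=Cc1ccc(S(=O)(=O)Nc2ccc3oc(-c4ccccc4)nc3c2)cc1`; in this assay compound 2 gives only a limit, > 63000 nM.
Compound 3 `O=S(=O)(Nc1ccc2oc(-c3ccccc3)nc2c1)c1cccs1`; in this assay compound 3 gives only a limit, > 63000 nM.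

Compound 1 therefore stands nowhere that can be placed on a scale: its value is a limit, as are the two others, which all sit at the limit of > 63000 nM in this assay, at which 3 of the 3 values shown sit. Among the measured compounds shown here, the one step between measured compounds, a step that the two limits leave unreadable from compound 2 to compound 3, is left unreadable by the two limits. Compound 4 `O=S(=O)(Nc1ccc(-c2nc3ccccc3o2)cc1)c1ccc(O)cc1` differs from compound 1 by 4-hydroxyphenyl in place of 3-fluorophenyl on a sulfonyl sulfur. For the measured compounds named here, no measured step bears on this change, so the expected step that the limit leaves unreadable from compound 1 to compound 4 is only a guess that compound 4 stays near the limit. Compound 4 is estimated at 100000 nM, between 30000 nM and 400000 nM.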

Compound 4, half-maximal inhibitory concentration: > 63000 nM
Compound 4 ended at the assay's limit; the forecaster's own chance of this, stated with the estimate: 85%; the middle value lies beyond the limit too.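

Compound 1 and compound 4 are both recorded only as limits, so no step can be read between them: the limit of > 63000 nM in this assay, at which 4 of the 4 values shown sit. On these data alone, what concentration would half-inhibit the enzyme for any of the four compounds in this assay remains open.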